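Inverting the Piperidine Stereocentre of a Weak Inhibitor

The compounds below may be only part of what the source reports. "The series", "measured", "known", "first", "only" and "open" are said of these compounds alone.

In an assay for inhibition of Indoleamine 2,3-dioxygenase 1 (Homo sapiens), with stated times of 10 min and 60 min (a higher number here means a weaker inhibitor, a lower number a stronger inhibitor), compound 1 `Oc1ccc(CNc2cc(C(F)(F)F)cc3[nH]ncc23)cc1` gives 36700 nM, and compound 2 `FC(F)(F)c1cc(NC[C@@H]2CCCCN2)c2cn[nH]c2c1` gives 18700 nM. Compound 2 stands alongside compound 1 within the scatter, since the step of a 2.0-fold lower number from compound 1 to compound 2 (0.29 log units; within the scatter) gives no separation between them. Compound 3 `FC(F)(F)c1cc(NC[C@H]2CCCCN2)c2cn[nH]c2c1` keeps every atom and bond of compound 2: the two compounds have the same atoms and bonds and differ only in configuration as drawn: 1 of 1 stereo elements differ; a stereocentre at a saturated ring carbon is drawn S in compound 2 and R in compound 3. For the measured compounds named here, no measured step bears on a change of configuration; the only step known, a 2.0-fold lower number from compound 1 to compound 2 (0.29 log units; within the scatter), concerns a different exchange and is itself within the scatter. The step of a 1.3-fold higher number from compound 2 to compound 3 (0.13 log units; within the scatter) is therefore expected to be none beyond the scatter, with wide uncertainty. The estimate for compound 3 is 25000 nM, ranging from 7000 nM to 90000 nM.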

Compound 3, half-maximal inhibitory concentration: 24000 nM
Beside the measured number, compound 3's estimate is 1.0-fold (0.02 log units) above it, and the stated range covers the measured number.
By their numbers in this assay, from the lowest: compounds 2, 3 and 1 (each within the scatter of the next).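

In this assay, inverting the stereocentre at the saturated ring carbon gives a 1.3-fold higher number from compound 2 to compound 3 (0.11 log units; within the scatter), so neither drawn configuration can be told apart from the other at this position, and the comparison isolates that one change: the fact that compounds 2 and 3 differ only in the configuration as drawn. With the R form, too, piperidin-2-yl in place of 4-hydroxyphenyl remains unresolved, at a 1.5-fold lower number from compound 1 to compound 3 (0.18 log units; within the scatter), as it did with the S form.

On these data alone, it remains open whether another group on this chain carbon, such as a cyclohexyl ring, a carboxylic acid or a longer chain, would produce a step beyond the scatter.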